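Macrolide amide series: heptyl amide replacing chloropyrazolyl amide

The source may report more compounds than this note shows. Statements on the series, on what has been measured and on what is new or still open speak of the compounds shown alone.

Two compounds of the series have a number in a physicochemical assay for lipophilicity, read by HPLC, measured as chromatographic lipophilicity, at pH 7.4; on this read-out higher numbers stand for higher lipophilicity and lower numbers for lower lipophilicity. Compound 1 `CC[C@H]1OC(=O)[C@H](C)[C@@H](O[C@H]2C[C@@](C)(OC)[C@@H](O)[C@H](C)O2)[C@H](C)[C@@H](O[C@@H]2O[C@H](C)C[C@H](N(C)C)[C@H]2O)[C@](C)(O)C[C@@H](C)CN(CCCNC(=O)c2c(C)nn(C)c2Cl)[C@H](C)[C@@H](O)[C@]1(C)O` gives 2.2 in this assay, the lower of the two numbers. Compound 2 `CCCCCCCC(=O)NCCCO[C@@H]1[C@@H](C)C(=O)[C@H](C)C[C@@](C)(OC)[C@H](O[C@@H]2O[C@H](C)C[C@H](N(C)C)[C@H]2O)[C@@H](C)[C@H](O[C@H]2C[C@@](C)(OC)[C@@H](O)[C@H](C)O2)[C@@H](C)C(=O)O[C@H](CC)[C@@]1(C)O` gives 5.07 in this assay, a number that lies above that of compound 1 by more than the scatter; the two compounds differ in several places, so their values are only set side by side here.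

Compound 3 `CCCCCCCC(=O)NCCCN1C[C@H](C)C[C@@](C)(O)[C@H](O[C@@H]2O[C@H](C)C[C@H](N(C)C)[C@H]2O)[C@@H](C)[C@H](O[C@H]2C[C@@](C)(OC)[C@@H](O)[C@H](C)O2)[C@@H](C)C(=O)O[C@H](CC)[C@@](C)(O)[C@H](O)[C@H]1C` has not yet been measured. Its relation to compound 1 is heptyl in place of 5-chloro-1,3-dimethyl-1H-pyrazol-4-yl on a carbonyl carbon. The change removes the aromatic ring with its two hydrogen-bond acceptors and the chlorine, and brings in a chain with no acceptors.

A rise in this assay is expected, since compound 2, which also carries the heptylcarbonyl amide, gives 5.07. The step from compound 1 to compound 3 is estimated at a number 1.40 log units higher from compound 1 to compound 3 (beyond the scatter), beyond the scatter. Compound 3 is estimated at 3.6, within 2.8 to 4.4.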

Compound 3, distribution coefficient: 3.74
Compound 3: the middle estimate sits 0.14 log units below what was measured; low and high end bracket the measured number.
By their numbers in this assay, from the lowest: compound 1; then compound 3; then compound 2.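

On a carbonyl carbon whose other neighbour is the amide-type nitrogen, heptyl in place of 5-chloro-1,3-dimethyl-1H-pyrazol-4-yl gives, in this assay, a number 1.54 log units higher from compound 1 to compound 3 (beyond the scatter), a large step. This is the only pair shown that differs in one place, so the group on this carbonyl carbon can now be tied to a change in the read-out, with the rest of the core held constant. Nothing measured here says which part of the exchanged groups accounts for the step.

Still open, as far as these compounds go, is how the number follows chain length at this place, for example with a pentyl or a decyl chain, and where a phenyl ring would fall relative to compound 1 and compound 3. Also open, from the compounds shown here alone, is what a terminal amine or carboxylic acid on the heptyl chain would do to the number.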